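Halogen Swap on the Benzyl Arm: Compound 3 to Compound 4

A few compounds are considered here, and "the series" means these few. Any claim that something is new, unique, unknown or untested is made for them only; others in the source may bear on it.

Three measured compounds share one core and differ only in the benzyl arm attached to the ring nitrogen. Compound 1 `O=C(/C=C/c1ccc(OCc2cn(Cc3ccccc3)nn2)cc1)c1ccc(Br)cc1` carries an unsubstituted benzyl group; in a functional assay on A549 cells (Homo sapiens) for inhibition, read by MTT assay, with a stated time of 48 h, tested at 10 uM (a higher number here means more inhibition of growth at the concentration tested, a lower number less inhibition of growth), compound 1 gives 34%. Compound 2 `O=C(/C=C/c1ccc(OCc2cn(Cc3ccccc3Br)nn2)cc1)c1ccc(Br)cc1` adds a bromine to that benzyl ring, and compound 2 gives 44%. Compound 3 `O=C(/C=C/c1ccc(OCc2cn(Cc3cccc(Br)c3)nn2)cc1)c1ccc(Br)cc1` carries a 3-bromophenyl where compound 2 carries a 2-bromophenyl, and compound 3 gives 44%. Compound 3 therefore stands level with compound 2, and the two share the highest of the three numbers, but neither is separated from compound 1 beyond the scatter: a number 10 percentage points higher from compound 1 to compound 3 (within the scatter), and no change at the digits printed from compound 2 to compound 3 (within the scatter).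

Compound 4 `O=C(/C=C/c1ccc(OCc2cn(Cc3ccccc3F)nn2)cc1)c1ccc(Br)cc1` is the next step: 2-fluorophenyl in place of 3-bromophenyl on a saturated chain carbon bound to an aromatic nitrogen. Among the compounds with values here, two measured steps bear on it. Adding a bromine to the benzyl ring gave only a number 10 percentage points higher from compound 1 to compound 3 (within the scatter), and shifting that bromine gave no change at the digits printed from compound 2 to compound 3 (within the scatter). So far the benzyl halogen has moved this assay little, whatever its placing. Within the data shown here, no fluorine-bearing compound has been measured, so the bromine-to-fluorine swap itself is untested. The expected step is therefore small or none beyond the scatter, a number 6 percentage points lower from compound 3 to compound 4 (within the scatter). Compound 4 is estimated at 38%, with a range from 24% to 52%.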

Compound 4, percent growth inhibition at one concentration: 38%
Beside the measured number, compound 4's estimate shows no gap at the digits printed, and the stated range covers the measured number.
By their numbers in this assay, from the lowest: compounds 1, 4, 2 and 3 (each within the scatter of the next).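

Within the data shown here, until now, the benzyl arm had carried only bromine or no halogen at all, and compound 4 shows that fluorine on this arm also gives no separation in this assay from any of the earlier compounds. With fluoro in place of bromo on an aromatic carbon, the step is a number 6 percentage points lower from compound 2 to compound 4 (within the scatter) and with fluoro in place of hydrogen it is a number 4 percentage points higher from compound 1 to compound 4 (within the scatter) while the change from 3-bromophenyl to 2-fluorophenyl is a number 6 percentage points lower from compound 3 to compound 4 (within the scatter) and so, across these four compounds, neither the presence of a halogen, nor its kind, nor the two placings of bromine can be told apart from the usual scatter of the measurement. No independent measurement is available to explain these numbers.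

On these data alone, every substituent on the benzyl ring here is a halogen, so it remains open whether a group of another kind, such as an amine, a carboxylic acid or a methoxy group, would produce a step beyond the scatter. As far as these compounds go, a longer chain in place of the saturated chain carbon that carries the ring is equally open.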